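A few compounds are considered here, and "the series" means these few. Any claim that something is new, unique, unknown or untested is made for them only; others in the source may bear on it.

Of the compounds shown here, three sharing one core have been tested in a functional assay on HEL cells (Homo sapiens) for cytotoxicity, read by microscopy; on this read-out higher numbers stand for lower toxicity in this test and lower numbers for higher toxicity in this test. Compound 2 `Cc1cn([C@@H]2O[C@H](CO[Si](C)(C)C(C)(C)C)[C@@]3(OS(=O)(=O)C=C3NC(=O)c3ccccc3)[C@H]2O[Si](C)(C)C(C)(C)C)c(=O)n(C)c1=O` carries a benzoyl group on an amine nitrogen. In this assay compound 2 gives only a limit, >= 3200 nM, so its true number is not known. Compound 1 `Cc1cn([C@@H]2O[C@H](CO[Si](C)(C)C(C)(C)C)[C@@]3(OS(=O)(=O)C=C3NCCC(=O)OCc3ccccc3)[C@H]2O[Si](C)(C)C(C)(C)C)c(=O)n(C)c1=O` also gives only a limit in this assay, namely >= 400000 nM. Compound 3 `Cc1cn([C@@H]2O[C@H](CO[Si](C)(C)C(C)(C)C)[C@@]3(OS(=O)(=O)C=C3NCCC(=O)O)[C@H]2O[Si](C)(C)C(C)(C)C)c(=O)n(C)c1=O` gives an actual number in this assay, 80000 nM. The steps a step that the two limits leave unreadable from compound 1 to compound 2 and a step that the limit leaves unreadable from compound 2 to compound 3 cannot be sized, as the limits the limit of >= 3200 nM in this assay, at which 1 of the 3 values shown sits, and the limit of >= 400000 nM in this assay, at which 1 of the 3 values shown sits, show; only an at least 5.0-fold lower number from compound 1 to compound 3 (0.69 log units; beyond the scatter) can be read. Compound 4 `COC(=O)CNC1=CS(=O)(=O)O[C@@]12[C@@H](CO[Si](C)(C)C(C)(C)C)O[C@@H](n1cc(C)c(=O)n(C)c1=O)[C@@H]2O[Si](C)(C)C(C)(C)C` is the new compound, and it differs from compound 2 by (methoxycarbonyl)methyl in place of benzoyl on an amine nitrogen. On these data alone, both steps that touch the benzoyl group are unreadable, so the direction from compound 2 stays open; compounds 1 and 3, which carry a 2-(benzyloxycarbonyl)ethyl or 2-carboxyethyl chain instead of benzoyl, both sit at high numbers. Compound 4 is therefore expected to give an estimated 100000 nM in this assay, somewhere between 20000 nM and 400000 nM. This corresponds to an expected step that the limit leaves unreadable from compound 2 to compound 4.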

Compound 4, minimum cytotoxic concentration: >= 400000 nM
Compound 4 gave a limit, no number; the forecaster's own chance of this, stated with the estimate: 40%; at least 4.0-fold (0.60 log units) between middle value and limit.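

On the amine nitrogen, (methoxycarbonyl)methyl in place of 2-carboxyethyl gives an at least 5.0-fold higher number from compound 3 to compound 4 (0.69 log units; beyond the scatter) in this assay. This adds a second ester, after compound 1, that sits well above compound 3, the only free carboxylic acid shown and the one compound that goes against this high-number pattern. The result for compound 4 is only a limit, the same one compound 1 gives: the limit of >= 400000 nM in this assay, at which 2 of the 4 values shown sit.

On these data alone, the steps joining compound 4 to compound 1 and compound 2 cannot be read, so how (methoxycarbonyl)methyl compares with benzoyl or 2-(benzyloxycarbonyl)ethyl stays open. The readable step changes the chain and its end group together, and a carboxymethyl or a 2-(methoxycarbonyl)ethyl group on the same nitrogen would separate the two changes.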